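Methoxyphenyl in place of ethoxymethylphenyl, sulfur-linked series

A few compounds are considered here, and "the series" means these few. Any claim that something is new, unique, unknown or untested is made for them only; others in the source may bear on it.

Two members of the series have been run in an assay on CHO cells for displacement of a labelled ligand from prostaglandin E2 receptor EP1 subtype (Mus musculus); on this read-out lower numbers stand for stronger inhibition and higher numbers for weaker inhibition. Compound 1, `CCCC[C@H](C)C[C@H](O)/C=C/[C@H]1[C@H](O)CC(=O)[C@@H]1SCCCCCC(=O)O`, gives 11 nM in this assay. Compound 2, `CCOCc1cccc(C[C@H](O)/C=C/[C@H]2[C@H](O)CC(=O)[C@@H]2SCCCSCC(=O)O)c1`, returns only a limit in this assay, > 10000 nM, so no number stands for it; it sits at the ceiling of the read-out (the limit of > 10000 nM in this assay, at which 1 of the 2 values shown sits). Going by the values given here, compound 1 and compound 2 differ in more than one place, so their two values show only that compound 1 binds tightly while compound 2 registers no number at all.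

Compound 3, `COc1ccc(C[C@H](O)/C=C/[C@H]2[C@H](O)CC(=O)[C@@H]2SCCCSCC(=O)O)cc1`, has not yet been measured. It differs from compound 2 by 4-methoxyphenyl in place of 3-(ethoxymethyl)phenyl on a saturated chain carbon, two bonds along the chain from a double-bonded chain carbon and an oxygen on a saturated carbon. No measured step between single-change neighbours exists in this set, so the size of this change cannot be read from the numbers shown. Because compound 2 reports > 10000 nM, the step that the limit leaves unreadable from compound 2 to compound 3 is estimated as none beyond the scatter in this assay, with a high chance that again only a limit is returned. The estimate for compound 3 in this assay is 15000 nM, range 3000 nM to 60000 nM.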

Compound 3, inhibition constant: 3100 nM
Estimate against measurement, compound 3: 4.8-fold (0.68 log units) above, and the stated range covers the measured number.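

In this assay, going by these compounds alone, 4-methoxyphenyl in place of 3-(ethoxymethyl)phenyl on this saturated chain carbon gives an at least 3.2-fold lower number from compound 2 to compound 3 (0.50 log units; beyond the scatter), the first readable evidence that the group at this carbon affects binding in the sulfur-linked series, and it shows that an aryl group here does not by itself rule out a numerical reading. On these data alone, the step is a minimum and its true size remains unknown, because compound 2 gives only a limit: the limit of > 10000 nM in this assay, at which 1 of the 3 values shown sits. The change replaces 3-(ethoxymethyl)phenyl with a smaller group, 4-methoxyphenyl, and also moves the ring substituent, so this single step cannot assign the difference to either the substituent or its place on the ring.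

A 3-methoxyphenyl or 4-(ethoxymethyl)phenyl group on the same carbon would separate those two contributions, while an unsubstituted phenyl would show whether either ether substituent is needed at all. Compound 1 differs from compound 3 in more than one place, so the shown data leave open which of those differences matters most, including whether a branched alkyl chain at this carbon would retain its binding in the sulfur-containing acid chain of compound 3.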